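A few compounds are considered here, and "the series" means these few. Any claim that something is new, unique, unknown or untested is made for them only; others in the source may bear on it.

Compound 1 `CC1(C)[C@H]2CC[C@]1(C)N(Cc1cn(-c3ccc(F)cc3)nn1)C(=O)C2` gives 90 nM.
Compound 2 `CC1(C)[C@H]2CC[C@]1(C)N(Cc1cn(-c3ccc(O)cc3)nn1)C(=O)C2` gives 80 nM.
Compound 3 `CC1(C)[C@H]2CC[C@]1(C)N(Cc1cn(-c3ccc(Br)cc3)nn1)C(=O)C2` gives 110 nM.

In a functional assay on HepG2 cells (Homo sapiens) for inhibition, read by MTT assay, with a stated time of 24 h (a lower number here means a stronger inhibitor, a higher number a weaker inhibitor), compound 1 sits between its two neighbours: a 1.1-fold lower number from compound 1 to compound 2 (0.05 log units; within the scatter) and a 1.2-fold higher number from compound 1 to compound 3 (0.09 log units; within the scatter), so all three numbers are indistinguishable within the scatter. Compound 4 `COc1ccc(-n2cc(CN3C(=O)C[C@@H]4CC[C@@]3(C)C4(C)C)nn2)cc1` differs from compound 1 by methoxy in place of fluoro on an aromatic carbon. The three measured steps all swap the group at this same place on the ring, and none of them moved the number beyond the scatter, including a 1.4-fold higher number from compound 2 to compound 3 (0.14 log units; within the scatter). A fourth swap at the same spot is therefore expected to leave the number essentially where compound 1 stands. Compound 4 is expected to give about 90 nM, within 45 nM to 180 nM. The expected step is no change at the digits printed from compound 1 to compound 4 (within the scatter).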

Compound 4, half-maximal inhibitory concentration: 100 nM
The estimate for compound 4 lay 1.1-fold (0.05 log units) below the measured number; the measured number falls inside the stated range.
By their numbers in this assay, from the lowest: compounds 2, 1, 4 and 3 (each within the scatter of the next).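

In this assay, the position on the aromatic ring also accepts methoxy, with its 2 heavy atoms and a hydrogen-bond acceptor, and the number stays within the scatter (a 1.1-fold higher number from compound 1 to compound 4 (0.05 log units; within the scatter)). The same holds against the other two groups (a 1.1-fold lower number from compound 3 to compound 4 (0.04 log units; within the scatter)), and capping the oxygen with methyl changes nothing beyond the scatter either (a 1.3-fold higher number from compound 2 to compound 4 (0.10 log units; within the scatter)). So far, no group tried at this place separates from the rest. From the compounds shown here alone, whether an amine, a carboxylic acid or a longer chain such as butoxy would do the same stays open. Nothing shown explains why these swaps leave the number in place.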